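The compounds below may be only part of what the source reports. "The series", "measured", "known", "first", "only" and "open" are said of these compounds alone.

Compound 1 `C=C(Br)C(=O)Nc1ccc(C(=O)/C=C/c2cccc(OC)c2OC)cc1` gives 710 nM in an ADME assay on CCRF-CEM cells (Homo sapiens) for antiproliferative activity, with a stated time of 48 h; a lower number here means a stronger inhibitor, a higher number a weaker inhibitor. Compound 2 `C=C(Br)C(=O)Nc1ccc(C(=O)/C=C/c2ccc(OC)c(OC)c2OC)cc1` gives 840 nM, so that the step of a 1.2-fold higher number from compound 1 to compound 2 (0.07 log units; within the scatter) follows from the change (methoxy in place of hydrogen on an aromatic carbon). Compound 3 `COc1cc(/C=C/C(=O)c2ccc(N)cc2)cc(OC)c1` carries a different core, and the difference between the two cores is not broken down here; in this assay compound 3 gives 5700 nM. Compound 4 `COc1cc(/C=C/C(=O)c2ccc(N)cc2)cc(OC)c1OC` is not yet measured and differs from compound 3 by methoxy in place of hydrogen on an aromatic carbon. For the measured compounds named here, this is the same kind of change as the one from compound 1 to compound 2, though not the same: the entering group here sits ortho to two methoxy groups, whereas before it sat ortho to a methoxy group and meta to a methoxy group. Because the earlier step was a 1.2-fold higher number from compound 1 to compound 2 (0.07 log units; within the scatter), compound 4 is expected to show a step of a 1.1-fold higher number from compound 3 to compound 4 (0.06 log units; within the scatter), giving an estimated 6500 nM, likely between 2500 nM and 17000 nM.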

Compound 4, half-maximal inhibitory concentration: 2300 nM
Compound 4: the middle estimate sits 2.8-fold (0.45 log units) above what was measured; the whole stated range lies above it.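

In this assay, methoxy in place of hydrogen on an aromatic carbon gives a 2.5-fold lower number from compound 3 to compound 4 (0.39 log units; beyond the scatter), whereas the same change on the core of compound 1 stayed within the scatter. The change therefore does not carry over with the same size from one core to the other: the same change on two cores in this assay, a 1.2-fold higher number (0.07 log units; within the scatter) from compound 1 to compound 2 and a 2.5-fold lower number (0.39 log units; beyond the scatter) from compound 3 to compound 4, 2.9-fold (0.47 log units) apart, beyond the scatter of two such steps. For the compounds shown here, only two pairs bear on this, and they differ both in core and in the groups around the entering methoxy, so the data do not show which of these sets the gap.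

Going by these compounds, it remains open whether an ethoxy or a hydroxy group at that aromatic carbon would give a step like that of methoxy. On these data alone, how the change behaves on any further core also remains open.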